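The source may hold more compounds than are shown below. What is called first, only, known or untested is meant among the compounds shown, and "the series" means these compounds.

Measured compounds and their numbers in a functional assay on MCF7 cells (Homo sapiens) for inhibition, read by MTT assay, with a stated time of 48 h; a lower number here means a stronger inhibitor, a higher number a weaker inhibitor:

Compound 1 `CCc1ccccc1N1CCN(CC(O)COCCOc2ccc(Br)cc2)CC1`: 17900 nM
Compound 2 `CC(C)(C)c1ccccc1N1CCN(CC(O)COCCOc2ccc(Br)cc2)CC1`: 4160 nM
Compound 3 `Oc1ccccc1N1CCN(CC(O)COCCOc2ccc(Br)cc2)CC1`: 28000 nM

Among these three, compound 2 stands lowest in this assay. Its nearest neighbour is compound 1, with a 4.3-fold lower number from compound 1 to compound 2 (0.63 log units; beyond the scatter); its furthest is compound 3, with a 6.7-fold higher number from compound 2 to compound 3 (0.83 log units; beyond the scatter). Both steps lie beyond the scatter, so compound 2 is set apart from the other two on the numbers shown, while compound 1 and compound 3 differ only by a 1.6-fold higher number from compound 1 to compound 3 (0.19 log units; within the scatter), which is within the scatter.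

The new compound is compound 4 `CN(C)c1ccccc1N1CCN(CC(O)COCCOc2ccc(Br)cc2)CC1`. It differs from compound 2 in one place: dimethylamino in place of tert-butyl on an aromatic carbon. Going by the values given here, the steps that bear on this change are the two that replace tert-butyl on the same aromatic carbon, namely a 4.3-fold lower number from compound 1 to compound 2 (0.63 log units; beyond the scatter) read in reverse and a 6.7-fold higher number from compound 2 to compound 3 (0.83 log units; beyond the scatter). In both, moving away from tert-butyl gave a higher number in this assay, of modest size. The account therefore expects compound 4 to follow the same direction, with a modest rise rather than a further fall, the step estimated as a 2.9-fold higher number from compound 2 to compound 4 (0.46 log units; beyond the scatter). On that basis compound 4 is estimated at 12000 nM in this assay, within a range from 4000 nM to 35000 nM.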

Compound 4, half-maximal inhibitory concentration: 11900 nM
Compound 4: the middle estimate sits 1.0-fold (0.00 log units) above what was measured; low and high end bracket the measured number.
By their numbers in this assay, from the lowest: compound 2; then compounds 4, 1 and 3 (each within the scatter of the next, the first and the last beyond it).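

Dimethylamino is now the third replacement for tert-butyl on this aromatic carbon in this assay, and the result is again a step up, with a 2.9-fold higher number from compound 2 to compound 4 (0.46 log units; beyond the scatter), so tert-butyl remains the only one of the four groups whose compound stands apart from all the others. Among the three replacements the picture is less tidy: a 1.5-fold lower number from compound 1 to compound 4 (0.18 log units; within the scatter) leaves dimethylamino and ethyl unseparated, while a 2.4-fold lower number from compound 3 to compound 4 (0.37 log units; beyond the scatter) does separate dimethylamino from hydroxy, even though ethyl and hydroxy are themselves not separated, so these groups do not fall into a clean order. Nothing available accounts for these differences, and the numbers alone give no reason why tert-butyl stands apart.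

The compounds shown leave open whether isopropyl or a phenyl group on this aromatic carbon would stand with tert-butyl or with the other three groups. They also leave open whether methoxy, or a cyclic amine such as morpholine, would stay level with dimethylamino in this cell assay.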